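This account rests on a few compounds, and the source may have more. Where it says the series, first, only, none or still open, it means among the compounds named here.

The three measured compounds share the core of compound 1 `COc1cc(/C=C/C(=O)c2cccc(NC(=O)C(C)C)c2)ccc1O`, which in a functional assay on B16 cells (Mus musculus) for inhibition (on this read-out higher numbers stand for weaker inhibition and lower numbers for stronger inhibition), gives 1.09 ug/mL. Compound 2 `COc1cc(/C=C/C(=O)c2cccc(NC(=O)c3ccccc3)c2)ccc1O` carries phenyl in place of isopropyl on a carbonyl carbon and gives 0.82 ug/mL in this assay; the step of a 1.3-fold lower number from compound 1 to compound 2 (0.12 log units; within the scatter). Compound 3 `CCOC(=O)C(=O)Nc1cccc(C(=O)/C=C/c2ccc(O)c(OC)c2)c1`, with ethoxycarbonyl on that carbonyl carbon, gives 7.03 ug/mL, the highest of the three numbers: the steps of a 6.4-fold higher number from compound 1 to compound 3 (0.81 log units; beyond the scatter) and an 8.6-fold higher number from compound 2 to compound 3 (0.93 log units; beyond the scatter) both lie beyond the scatter. Compound 4 `COc1cc(/C=C/C(=O)c2cccc(NC(=O)c3cccs3)c2)ccc1O` differs from compound 3 by thiophen-2-yl in place of ethoxycarbonyl on a carbonyl carbon. Thiophen-2-yl, like phenyl, is an aromatic ring on the carbonyl carbon, and the closest comparison is therefore the step in which phenyl gave way to ethoxycarbonyl; read backwards, an 8.6-fold higher number from compound 2 to compound 3 (0.93 log units; beyond the scatter) points to a markedly lower number when a ring returns. The step in which isopropyl gave way to ethoxycarbonyl, a 6.4-fold higher number from compound 1 to compound 3 (0.81 log units; beyond the scatter), points the same way. For compound 4 the expected step is therefore a 7.8-fold lower number from compound 3 to compound 4 (0.89 log units; beyond the scatter). Compound 4 is thus estimated at 0.9 ug/mL in this assay, with a range from 0.4 ug/mL to 2.2 ug/mL.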

Compound 4, half-maximal inhibitory concentration: 6.93 ug/mL
Compound 4: the middle estimate sits 7.7-fold (0.89 log units) below what was measured, and the stated range ends below it.
By their numbers in this assay, from the lowest: compounds 2 and 1 (each within the scatter of the next); then compounds 4 and 3 (each within the scatter of the next).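

The result separates two aromatic rings on this carbonyl carbon, whose other neighbour is the amide-type nitrogen. In this assay, thiophen-2-yl does not behave like phenyl, with an 8.5-fold higher number from compound 2 to compound 4 (0.93 log units; beyond the scatter), while replacing ethoxycarbonyl with the ring leaves the read-out unchanged within the scatter, with a 1.0-fold lower number from compound 3 to compound 4 (0.01 log units; within the scatter). The step from isopropyl, a 6.4-fold higher number from compound 1 to compound 4 (0.80 log units; beyond the scatter), confirms that having a ring does not sort these four compounds: isopropyl without a ring and phenyl with one sit together at the low end, while ethoxycarbonyl without a ring and thiophen-2-yl with one sit together at the high end. No measurement offered here explains why the phenyl and thiophen-2-yl compounds part in this way.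

The compounds shown leave open whether the higher number belongs to thiophen-2-yl in particular or extends to other five-membered aromatic rings, such as furan-2-yl or thiophen-3-yl. They also leave open how a pyridin-3-yl ring, a longer chain such as n-butyl, or a carboxylic acid in place of the ethyl ester would read at this carbonyl carbon.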